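This account rests on a few compounds, and the source may have more. Where it says the series, first, only, none or still open, it means among the compounds named here.

Compound 1 `CC(=O)N1CCN(c2ccc(OCC3CCN(C(=O)OC(C)C)CC3)cn2)CC1` — in a functional assay on CHO-K1 cells for agonist activity at Glucose-dependent insulinotropic receptor (Homo sapiens), read by a luciferase reporter, with a stated time of 5 h (on this read-out lower numbers stand for an effect already at smaller amounts and higher numbers for an effect only at larger amounts of compound), compound 1 reaches only the assay limit, > 10000 nM.
Compound 2 `CC(C)OC(=O)N1CCC(COc2ccc(N3CCN(S(=O)(=O)C(C)C)CC3)nc2)CC1` — compound 2 gives 300 nM in this assay.

Among the compounds with values here, compound 2 thus holds the only actual number recorded; the other value is the limit of > 10000 nM in this assay, at which 1 of the 2 values shown sits. Within the data shown here, the single measured step, an at least 33-fold lower number from compound 1 to compound 2 (1.52 log units; beyond the scatter), replaced an acetyl on the ring nitrogen with isopropylsulfonyl. Compound 3 `CCCS(=O)(=O)N1CCN(c2ccc(OCC3CCN(C(=O)OC(C)C)CC3)cn2)CC1` differs from compound 2 by propyl in place of isopropyl on a sulfonyl sulfur. Among the measured compounds shown here, no measured step alters the alkyl on the sulfonyl itself, so the large step offers no direct guide here. For compound 3 a step within the scatter is expected, a 1.2-fold higher number from compound 2 to compound 3 (0.07 log units; within the scatter). Compound 3 is estimated at 350 nM, between 140 nM and 900 nM.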

Compound 3, half-maximal effective concentration: 300 nM
Compound 3: the middle estimate sits 1.2-fold (0.07 log units) above what was measured; measured number inside the range.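

On the sulfonyl sulfur, propyl and isopropyl are not told apart in this assay: no change at the digits printed from compound 2 to compound 3 (within the scatter). Propylsulfonyl in place of acetyl on the amine nitrogen in the ring gives an at least 33-fold lower number from compound 1 to compound 3 (1.52 log units; beyond the scatter), so a large step now appears with two different sulfonyl groups. Compound 1 holds a limit and not a number, so the full size of this step stays unknown: the limit of > 10000 nM in this assay, at which 1 of the 3 values shown sits.

The compounds shown leave open how a longer chain such as butyl, a cyclopropyl or a phenyl on the sulfonyl sulfur would read out. Going by these compounds, whether a urea or a methylsulfonyl on that ring nitrogen would match these sulfonyl groups also remains open.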